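The compounds below may be only part of what the source reports. "The series", "measured", "known", "first", "only" and "open" are said of these compounds alone.

Compound 1 `CCn1c(C(=O)NCCC(=O)OC)ccc1C(CC)(CC)c1ccc(C#CC(O)(CC)CC)c(C)c1` is known in an assay on cells for agonist activity at vitamin D3 receptor (Homo sapiens), read by microscopy (on this read-out lower numbers stand for an effect already at smaller amounts and higher numbers for an effect only at larger amounts of compound), only as a limit, > 50 nM. Compound 2 `CCN(CC)CCCNC(=O)c1ccc(C(CC)(CC)c2ccc(C#CC(O)(CC)CC)c(C)c2)n1CC` gives 68.9 nM in this assay. Compound 3 `CCn1c(C(=O)NCCC(=O)O)ccc1C(CC)(CC)c1ccc(C#CC(O)(CC)CC)c(C)c1` gives 293 nM in this assay. For the measured compounds named here, because compound 1 sits at the limit (the limit of > 50 nM in this assay, at which 1 of the 3 values shown sits), the steps a step that the limit leaves unreadable from compound 1 to compound 2 and a step that the limit leaves unreadable from compound 1 to compound 3 cannot be sized; the only readable step is a 4.3-fold higher number from compound 2 to compound 3 (0.63 log units; beyond the scatter). Compound 4 `CCn1c(C(=O)NCCCO)ccc1C(CC)(CC)c1ccc(C#CC(O)(CC)CC)c(C)c1` differs from compound 1 by hydroxymethyl in place of methoxycarbonyl on a saturated chain carbon, two bonds along the chain from an amide-type nitrogen. Going by the values given here, no measured step covers this change; compound 2 and compound 3 show only that two other replacements at this position both give numbers in the same broad region. The step expected from this change is a step that the limit leaves unreadable from compound 1 to compound 4. For compound 4 the estimate in this assay is 120 nM, expected to lie between 40 nM and 400 nM.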

Compound 4, half-maximal effective concentration: 137 nM
Compound 4: the middle estimate sits 1.1-fold (0.06 log units) below what was measured; low and high end bracket the measured number.
By their numbers in this assay, from the lowest: compounds 2 and 4 (each within the scatter of the next); then compound 3.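

In this assay, hydroxymethyl at this place separates from carboxy, with a 2.1-fold lower number from compound 3 to compound 4 (0.33 log units; beyond the scatter), but not from the diethylamino-ended chain, with a 2.0-fold higher number from compound 2 to compound 4 (0.30 log units; within the scatter). Of the three groups with readable numbers here, carboxy alone stands apart from the other two. The step from compound 1 to compound 4 cannot be read, as compound 1 is known only as a limit: the limit of > 50 nM in this assay, at which 1 of the 4 values shown sits.

Where the methoxycarbonyl of compound 1 stands against these groups remains open. Also open, as far as these compounds go, is whether a primary amine or a longer chain ending in hydroxy would fall with compound 2 and compound 4 or with compound 3.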